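Swapping the Five-Membered Aromatic Ring Once More

The source may hold more compounds than are shown below. What is called first, only, known or untested is meant among the compounds shown, and "the series" means these compounds.

Compound 2 `Clc1ccc(N2N=C(CNN3CCOCC3)CC2c2ccco2)c(Cl)c1` stands higher of the two measured compounds: in a functional assay on the whole organism (strain Zucker) for inhibition, with Rattus norvegicus as the target, with a stated time of 4 h, at a dose of 10 mg/kg by the oral route (a higher number here means more inhibition at the dose given (going by the name of the read-out), a lower number less inhibition), compound 2 gives 15.1%, while compound 1 `Clc1ccc(N2N=C(CNN3CCOCC3)CC2c2cccs2)c(Cl)c1` gives 3%. Going by the values given here, the single measured step, a number 12.1 percentage points higher from compound 1 to compound 2 (beyond the scatter), shows that exchanging one five-membered aromatic ring for the other shifts the read-out beyond the scatter. Compound 3 `Cc1ccc(C2CC(CNN3CCOCC3)=NN2c2ccc(Cl)cc2Cl)s1` alters compound 2 by 5-methylthiophen-2-yl in place of furan-2-yl on a saturated ring carbon. This change returns toward the ring of compound 1 with one added methyl, so a modest fall is expected, namely a number 9.1 percentage points lower from compound 2 to compound 3 (within the scatter). The estimate for compound 3 is 6%, expected to lie between -6% and 18%.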

Compound 3, a percentage reported as inhibition, in the whole organism at one dose (the size of the read-out at that dose, not a potency): 9.3%
Estimate against measurement, compound 3: 3.3 percentage points below, within the range that was stated.
By their numbers in this assay, from the lowest: compounds 1, 3 and 2 (each within the scatter of the next, the first and the last beyond it).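

Placing 5-methylthiophen-2-yl on this saturated ring carbon gives a number 5.8 percentage points lower from compound 2 to compound 3 (within the scatter) in this assay, so here this exchange cannot be told apart from furan-2-yl. Adding the methyl to the thiophene ring gives a number 6.3 percentage points higher from compound 1 to compound 3 (within the scatter) and also stays within the usual variation, which shows that this small addition to the ring has no readable effect in this assay. No supporting data are available to explain these results. On these data alone, whether a phenyl ring on this carbon, or a carboxylic acid in place of the methyl, would move the read-out beyond the scatter remains open.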